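A Chloro on the Core: Following Compound 1 to Compound 3

The source may report more compounds than this note shows. Statements on the series, on what has been measured and on what is new or still open speak of the compounds shown alone.

Compound 1 `O=C(NS(=O)(=O)c1ccccc1)n1ccc2cccnc21` is the starting point. In a functional assay on MCF7 cells (Homo sapiens) for antiproliferative activity, read by MTT assay, with a stated time of 24 h, tested at 10 uM (a lower number here means less inhibition, a higher number more inhibition at the concentration tested (going by the name of the read-out)), compound 1 gives 19%, the lower of the two numbers recorded; its nearest neighbour is compound 2 `O=C(NS(=O)(=O)c1cccc([N+](=O)[O-])c1)n1ccc2cccnc21`, which gives 70.7%. For the measured compounds named here, the only measured step, a number 51.7 percentage points higher from compound 1 to compound 2 (beyond the scatter), puts a nitro in place of hydrogen on an aromatic carbon. Compound 3 `O=C(NS(=O)(=O)c1ccccc1)n1ccc2c(Cl)ccnc21` differs from compound 1 elsewhere: chloro in place of hydrogen on an aromatic carbon, on the six-membered aromatic ring with one nitrogen of the shared core, opposite the ring nitrogen. Going by the values given here, no measured step touches this part of the core, so the large rise seen with compound 2 bears on compound 3 only as a sign that a single heavy atom can move the read-out a great deal. Without direct precedent, a small rise or none beyond the scatter is expected, a number 11 percentage points higher from compound 1 to compound 3 (beyond the scatter). Compound 3 is therefore estimated at 30%, within a range from 12% to 55%.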

Compound 3, a percentage reported as inhibition, at one concentration (the size of the read-out at that concentration, not a potency): 3.32%
The estimate for compound 3 lay 26.7 percentage points above the measured number; the whole stated range lies above it.
By their numbers in this assay, from the lowest: compound 3; then compound 1; then compound 2.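

In this assay, chloro in place of hydrogen on an aromatic carbon of the shared core, opposite the ring nitrogen, produces a number 15.7 percentage points lower from compound 1 to compound 3 (beyond the scatter), a modest step. For the compounds shown here, this is the first measured change on the core, and it shows that the read-out responds to a single chlorine at this position and that this change lowers the number, while the only earlier step, made elsewhere in the molecule, raised it. Nothing in the material shown explains the fall.

The compounds shown leave open whether the fall is specific to chloro or would also follow from another group at this position, such as fluoro, methoxy or an amine. They also leave open how chloro on the core and nitro would act together in one molecule.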